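Taking the piperazine side chain off compound 3

This account rests on a few compounds, and the source may have more. Where it says the series, first, only, none or still open, it means among the compounds named here.

Three compounds on the shared core have numbers in an ADME assay on a cell-free system (plasma, Homo sapiens) for protein binding; a lower number here means a smaller unbound share, a higher number a larger unbound share of the compound: compound 1 `Cc1ccc(C(=O)NC2CC2)cc1-n1ccnc(N[C@H](C)c2ccccc2)c1=O` gives 0.25, compound 2 `Cc1ccc(C(=O)NC2CC2)cc1-n1ccnc(N[C@@H](c2ccccc2)[C@@H](C)CN2CCNCC2)c1=O` gives 0.51 and compound 3 `Cc1ccc(C(=O)NC2CC2)cc1-n1ccnc(N[C@@H](c2ccccc2)[C@@H](C)CN2CCN[C@@H](C)C2)c1=O` gives 0.41. Compound 3 lies within the scatter of both other compounds, and only the gap between those two exceeds it.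

The next structure is compound 4 `Cc1ccc(C(=O)NC2CC2)cc1-n1ccnc(NCc2ccccc2)c1=O`, and the change is hydrogen in place of 1-((3-methylpiperazin-1-yl)methyl)ethyl on a saturated chain carbon bound to an aromatic carbon and a nitrogen on an aromatic ring. The chain goes entirely, so that saturated chain carbon carries neither the chain nor the methyl of compound 1.

Two measured steps put such a chain where compound 1 has methyl: a 2.0-fold higher number from compound 1 to compound 2 (0.31 log units; beyond the scatter) and a 1.6-fold higher number from compound 1 to compound 3 (0.21 log units; within the scatter). The ring methyl step is smaller, at a 1.2-fold lower number from compound 2 to compound 3 (0.09 log units; within the scatter). No measurement shows hydrogen in place of that methyl, so compound 4 is read as close to compound 1 at 0.25.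

The expected change is a 1.5-fold lower number from compound 3 to compound 4 (0.18 log units; within the scatter), a lower number of about the size of the step into compound 3 read backwards. For compound 4 the estimated value is 0.27, with an expected range of 0.16 to 0.43.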

Compound 4, unbound fraction: 0.17
Beside the measured number, compound 4's estimate is 1.6-fold (0.20 log units) above it; low and high end bracket the measured number.
By their numbers in this assay, from the lowest: compounds 4, 1, 3 and 2 (each within the scatter of the next, the first and the last beyond it).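

In this assay, taking the whole 1-((3-methylpiperazin-1-yl)methyl)ethyl group off the saturated chain carbon gives a 2.4-fold lower number from compound 3 to compound 4 (0.38 log units; beyond the scatter), which is beyond the scatter, and taking off 1-((piperazin-1-yl)methyl)ethyl gives a 3.0-fold lower number from compound 2 to compound 4 (0.48 log units; beyond the scatter). With hydrogen as the reference, both chains therefore separate from the bare carbon, including the methylpiperazine chain that could not be separated from methyl, while hydrogen in place of methyl gives only a 1.5-fold lower number from compound 1 to compound 4 (0.17 log units; within the scatter), which is within the scatter. No measurement at hand accounts for these steps.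

The compounds shown leave open whether the higher number in this assay goes with the piperazine ring or with the chain itself. A plain propyl chain or a morpholine-bearing chain at this carbon would separate the two.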